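The source may hold more compounds than are shown below. What is called first, only, known or untested is meant among the compounds shown, and "the series" means these compounds.

Compound 1 `COc1ccc(/C=C/c2cc(OC)cc(OC)c2/C=C/C(=O)c2ccccc2)cc1`: in a functional assay on A549 cells (Homo sapiens) for antiproliferative activity, read by MTT assay, with a stated time of 48 h (on this read-out lower numbers stand for stronger inhibition and higher numbers for weaker inhibition), compound 1 gives 3.9 ug/mL.
Compound 2 `COc1ccc(/C=C/c2cc(OC)cc(OC)c2/C=C/C(=O)c2ccc(C(F)(F)F)cc2)cc1`: in this assay compound 2 gives 7.8 ug/mL.
Compound 3 `COc1ccc(/C=C/c2cc(OC)cc(OC)c2/C=C/C(=O)c2ccc(-c3ccccc3)cc2)cc1`: in this assay compound 3 gives 4.6 ug/mL.

Among these three, compound 2 carries the highest number, yet its distances to the others are small: a 2.0-fold higher number from compound 1 to compound 2 (0.30 log units; within the scatter) and a 1.7-fold lower number from compound 2 to compound 3 (0.23 log units; within the scatter) both stay within the scatter, as does a 1.2-fold higher number from compound 1 to compound 3 (0.07 log units; within the scatter). The three values therefore cannot be ordered with any confidence.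

Compound 4 `COc1ccc(/C=C/c2cc(OC)cc(OC)c2/C=C/C(=O)c2ccc(Cl)cc2)cc1` differs from compound 2 in one place: chloro in place of trifluoromethyl on an aromatic carbon. Going by the values given here, no measured pair exchanges these two groups directly. The two steps that touch the same aromatic carbon, a 2.0-fold higher number from compound 1 to compound 2 (0.30 log units; within the scatter) and a 1.7-fold lower number from compound 2 to compound 3 (0.23 log units; within the scatter), show that exchanging hydrogen for trifluoromethyl, or trifluoromethyl for phenyl, moves the number only within the scatter. Compound 4 is therefore expected to sit close to compound 2, with at most a slight move toward the numbers of compound 1 and compound 3. For compound 4 the expected step is a 1.6-fold lower number from compound 2 to compound 4 (0.19 log units; within the scatter). For compound 4 the estimated value in this assay is 5 ug/mL, within a range from 2.5 ug/mL to 10 ug/mL.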

Compound 4, half-maximal inhibitory concentration: 6.4 ug/mL
The estimate for compound 4 lay 1.3-fold (0.11 log units) below the measured number; measured number inside the range.
By their numbers in this assay, from the lowest: compounds 1, 3, 4 and 2 (each within the scatter of the next).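

In this assay, chloro at this place, on an aromatic carbon para to a large group, produces only small steps: a 1.2-fold lower number from compound 2 to compound 4 (0.09 log units; within the scatter), a 1.4-fold higher number from compound 3 to compound 4 (0.14 log units; within the scatter) and a 1.6-fold higher number from compound 1 to compound 4 (0.22 log units; within the scatter). Chloro thus joins hydrogen, trifluoromethyl and phenyl as a fourth group at this position, and no pair among the four compounds differs beyond the scatter, so the series still has no order here. No measurement is available that would account for this flat result.

The compounds shown leave open whether an amine or a carboxylic acid at this same carbon would give a step beyond the scatter. They also leave open how the number responds to a change elsewhere on the shared core, since all four compounds differ only at this one position.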